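The compounds below may be only part of what the source reports. "The series", "measured", "known", "first", "only" and "open" are said of these compounds alone.

For the measured compounds named here, in a functional assay on MDA-MB-231 cells (Homo sapiens) for inhibition, read by CCK-8 assay, with a stated time of 48 h (on this read-out lower numbers stand for stronger inhibition of growth and higher numbers for weaker inhibition of growth), compound 2 `Cc1ccccc1Nc1nc(Nc2ccccn2)ncc1Cl` gives 11200 nM, the only real number so far. Compound 1 `Cc1ccccc1Nc1nc(NCc2ccco2)ncc1Cl` shows only a limit of the assay, > 100000 nM. Compound 3 `Cc1ccccc1Nc1nc(NCc2ccncc2)ncc1Cl` likewise shows only a limit, > 100000 nM. Compound 4 `Cc1ccccc1Nc1nc(Nc2ccc(N3CCCCC3)cn2)ncc1Cl` alters compound 2 in one place: piperidin-1-yl in place of hydrogen on an aromatic carbon, with piperidin-1-yl in place of hydrogen on an aromatic carbon. Going by the values given here, no measured step tests such an addition directly. Two steps that swap the group on this side of the molecule, an at least 8.9-fold lower number from compound 1 to compound 2 (0.95 log units; beyond the scatter) and an at least 8.9-fold higher number from compound 2 to compound 3 (0.95 log units; beyond the scatter), do show that changes here can move the result in this assay beyond the scatter. A modest drop is therefore expected, a 3.7-fold lower number from compound 2 to compound 4 (0.57 log units; beyond the scatter), though the direction is uncertain. For compound 4 the estimated value is 3000 nM, with an expected range from 500 nM to 20000 nM.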

Compound 4, concentration for 50% growth inhibition: > 100000 nM
Compound 4: no number, only a limit; the forecaster's own chance of this, stated with the estimate: 10%; middle value at least 33-fold (1.52 log units) away from the limit.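

Until now, only swaps of the whole group on this side had been seen. Here, adding piperidin-1-yl on an aromatic carbon of the pyridin-2-yl ring, with nothing else changed, gives an at least 8.9-fold higher number from compound 2 to compound 4 (0.95 log units; beyond the scatter) in this assay, so an addition at this carbon alone can weaken growth inhibition. The full size of this step cannot be read, since compound 4 ends at a limit: the limit of > 100000 nM in this assay, at which 3 of the 4 values shown sit.

Still open, going by these compounds, is whether a small methyl or methoxy at this carbon, or an open-chain dimethylamino, would keep the growth inhibition of compound 2.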